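A few compounds are considered here, and "the series" means these few. Any claim that something is new, unique, unknown or untested is made for them only; others in the source may bear on it.

Compound 1 `COC(=O)/C=C/c1cccc(N(Cc2ccc(-c3cccc(OC)c3)cc2)C(=O)NC(C)C)c1` gives 1370 nM.
Compound 2 `COC(=O)/C=C/c1cccc(N(Cc2ccc(-c3ccc(SC)cc3)cc2)C(=O)C2CCCCC2)c1` gives 69 nM.
Compound 3 `COC(=O)/C=C/c1cccc(N(Cc2ccc(-c3cccc(OC)c3)cc2)C(=O)C(C)C)c1` gives 72 nM.

In an assay on isolated protein with Bile acid receptor (Homo sapiens) as the target (on this read-out higher numbers stand for an effect only at larger amounts of compound and lower numbers for an effect already at smaller amounts), compound 1 stands highest of the three numbers; compound 3 is its nearest neighbour, reached by a 19-fold lower number from compound 1 to compound 3 (1.28 log units; beyond the scatter), and compound 2 lies furthest away. Compound 4 `COC(=O)/C=C/c1cccc(N(Cc2ccc(-c3cccc(Cl)c3)cc2)C(=O)NC(C)C)c1` differs from compound 1 only in chloro in place of methoxy on an aromatic carbon. Going by the values given here, no measured step touches this part of the molecule: the single recorded step, from compound 1 to compound 3, changes the group on the carbonyl carbon instead, and compound 2 differs from compound 1 in more than one place, so its value alone says nothing about the chloro-for-methoxy exchange. With nothing to point either way, the expected step in this assay is a 1.0-fold higher number from compound 1 to compound 4 (0.01 log units; within the scatter), nothing beyond the scatter. Compound 4 is therefore estimated at 1400 nM, with a range from 450 nM to 4500 nM.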

Compound 4, half-maximal effective concentration: 1400 nM
Compound 4: middle estimate and measured number agree at the digits printed; low and high end bracket the measured number.
By their numbers in this assay, from the lowest: compounds 2 and 3 (each within the scatter of the next); then compounds 1 and 4 (each within the scatter of the next).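

In this assay the exchange of 3-methoxyphenyl for 3-chlorophenyl gives a 1.0-fold higher number from compound 1 to compound 4 (0.01 log units; within the scatter) and so shows that this position accepts the change, even though a hydrogen-bond acceptor leaves with the methoxy. The earlier step, a 19-fold lower number from compound 1 to compound 3 (1.28 log units; beyond the scatter), concerned only the group on the carbonyl carbon. No measured evidence accounts for why the two groups read alike.

From the compounds shown here alone, whether chloro behaves the same way with the isopropyl on the carbonyl carbon of compound 3 stays open. So does the effect of an amine, a carboxylic acid or a longer chain on this aromatic carbon.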